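Extending the chain of a pentenamide inhibitor by one carbon

The source may report more compounds than this note shows. Statements on the series, on what has been measured and on what is new or still open speak of the compounds shown alone.

Measured compounds:
compound 1 `CCC/C=C/C(=O)Nc1cccc(Oc2nc(Nc3cccc(OC)c3)nc3ccsc23)c1` — 7730 nM
compound 2 `C/C=C/C(=O)Nc1cccc(Oc2nc(Nc3cccc(C#N)c3)nc3ccsc23)c1` — 23600 nM
compound 3 `CC/C=C/C(=O)Nc1cccc(Oc2nc(Nc3cccc(C#N)c3)nc3ccsc23)c1` — 69400 nM

In a functional assay on HeLa cells (Homo sapiens) for inhibition, read by MTT assay, with a stated time of 72 h (on this read-out lower numbers stand for stronger inhibition and higher numbers for weaker inhibition), compound 3 gives the highest number of the three, with compound 2 nearest and compound 1 furthest away. Compound 4 `CCC/C=C/C(=O)Nc1cccc(Oc2nc(Nc3cccc(C#N)c3)nc3ccsc23)c1` differs from compound 3 by methyl in place of hydrogen on a saturated chain carbon, two bonds along the chain from a double-bonded chain carbon. Within the data shown here, the only measured step of the same kind is a 2.9-fold higher number from compound 2 to compound 3 (0.47 log units; beyond the scatter), which made the number larger. Compound 1 carries the same longer chain as compound 4 but a different group on the other ring, so its number only shows that such a chain can sit in a more potent compound. Compound 4 is therefore expected to come out near compound 3 or slightly weaker, a step of a 1.3-fold higher number from compound 3 to compound 4 (0.11 log units; within the scatter), with an estimate of 90000 nM and a range from 30000 nM to 270000 nM.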

Compound 4, half-maximal inhibitory concentration: 42100 nM
Compound 4: the middle estimate sits 2.1-fold (0.33 log units) above what was measured, within the range that was stated.
By their numbers in this assay, from the lowest: compound 1; then compounds 2, 4 and 3 (each within the scatter of the next, the first and the last beyond it).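

In this assay, methyl in place of hydrogen on the chain gives a 1.6-fold lower number from compound 3 to compound 4 (0.22 log units; within the scatter) and ethyl in place of hydrogen gives a 1.8-fold higher number from compound 2 to compound 4 (0.25 log units; within the scatter), so this longer chain cannot be told apart from either shorter chain. The rise seen on the first extension, a 2.9-fold higher number from compound 2 to compound 3 (0.47 log units; beyond the scatter), does not continue at this position. With the chain unchanged, cyano in place of methoxy on an aromatic carbon gives a 5.4-fold higher number from compound 1 to compound 4 (0.74 log units; beyond the scatter), a step that the chain changes to this compound do not match in clarity.

As far as these compounds go, whether a still longer chain, or an amine at its end, would stay in this range remains open. Nothing shown here explains any of these steps.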